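Chloro to methyl on the hydroxy compound

This account rests on a few compounds, and the source may have more. Where it says the series, first, only, none or still open, it means among the compounds named here.

Measured so far in a functional assay on MCF7 cells (Homo sapiens) for antiproliferative activity, read by MTT assay, with a stated time of 72 h; on this read-out lower numbers stand for stronger inhibition and higher numbers for weaker inhibition
- compound 1 `O=C1C=C(N2CCN(c3ccccc3Cl)CC2)C(=O)c2ccccc21` gives 10300 nM
- compound 2 `O=C1C=C(N2CCN(c3ccccc3Cl)CC2)C(=O)c2c(O)cccc21` gives 23800 nM

Compound 2 stands highest of the two numbers. Going by the values given here, the one measured step is a 2.3-fold higher number from compound 1 to compound 2 (0.36 log units; beyond the scatter) for hydroxy in place of hydrogen on an aromatic carbon. Compound 3 `Cc1ccccc1N1CCN(C2=CC(=O)c3cccc(O)c3C2=O)CC1` differs from compound 2 by methyl in place of chloro on an aromatic carbon, ortho to a large group, counted as methyl in place of chloro on an aromatic carbon with 2-chlorophenyl becoming 2-methylphenyl. Among the compounds with values here, no measured pair compares chloro with methyl, and a 2.3-fold higher number from compound 1 to compound 2 (0.36 log units; beyond the scatter) concerns a different change, so it serves only as a loose guide to size. A step within the scatter is therefore expected in this assay with no favoured direction. The expected step is a 1.1-fold lower number from compound 2 to compound 3 (0.03 log units; within the scatter) and remains an estimate. Compound 3 is estimated at 22000 nM with an expected range of 10000 nM to 48000 nM in this assay.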

Compound 3, half-maximal inhibitory concentration: 9700 nM
Compound 3: middle estimate off by 2.3-fold (0.36 log units), on the high side; the whole stated range lies above it.
By their numbers in this assay, from the lowest: compounds 3 and 1 (each within the scatter of the next); then compound 2.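

In this assay, the substituent on the 2-chlorophenyl ring is the second place in the series shown to move the number: methyl in place of chloro gives a 2.5-fold lower number from compound 2 to compound 3 (0.39 log units; beyond the scatter). Going by these compounds alone, the earlier compounds showed only the effect of hydroxy on the shared core, so this is the first sign that the aromatic carbon ortho to a large group also responds to substitution. The swap exchanges one heavy atom for one heavy atom, with no hydrogen-bond donors or acceptors counted on either side, yet the step is still beyond the scatter, and nothing available explains it.

Going by these compounds, it remains open whether methyl in place of chloro gives a similar step in the absence of the hydroxy group. On these data alone, it is also open how a methoxy group, a fluorine or an amine at this position would compare.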